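This account rests on a few compounds, and the source may have more. Where it says the series, first, only, none or still open, it means among the compounds named here.

Measured in a functional assay on the whole organism for positive allosteric modulation, with Mus musculus as the target (a higher number here means that more compound is needed for the effect, a lower number that less compound is needed), so far:
- compound 1 `CCC(=O)N(c1ccc(OC)cc1)C1CCCC1N(C)C` gives 30 mg/kg; 30 mg/kg (2 entries)
- compound 2 `CCC(=O)N(c1ccc(Cl)c(Cl)c1)C1CCCC1N` gives 0.02 mg/kg

Among the compounds with values here, compound 2 stands at 0.02 mg/kg, the only number available for it, and one further entry for it gives no single number. Within the data shown here, that dose lies far under the one needed by compound 1, but the two compounds differ in more than one place. Compound 1 at 30 mg/kg; 30 mg/kg (2 entries) therefore cannot isolate any single change.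

The next compound, compound 3 `C=CCN(C)C1CCCC1N(C(=O)CC)c1ccc(Cl)c(Cl)c1`, keeps the rest of compound 2 and changes one group: allyl(methyl)amino in place of amino on a saturated ring carbon. In words, allyl(methyl)amino takes the place of amino on a saturated ring carbon. Among the measured compounds shown here, no measured pair tests this change on its own, so the expectation is uncertain. The large gap between the two measured compounds leaves room for a sizeable loss, and a shift toward a higher dose, beyond the usual scatter, seems more likely than none. The expected change is a 25-fold higher number from compound 2 to compound 3 (1.40 log units; beyond the scatter) in this assay. For compound 3 the estimated dose is 0.5 mg/kg, with an expected range from 0.03 mg/kg to 8 mg/kg.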

Compound 3, dose for half-maximal effect: 0.2 mg/kg
The estimate for compound 3 lay 2.5-fold (0.40 log units) above the measured number; low and high end bracket the measured number.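

Within the data shown here, compound 3 provides the first comparison that changes only one place: in this assay, allyl(methyl)amino in place of amino on a saturated ring carbon gives a 10-fold higher number from compound 2 to compound 3 (1.00 log units; beyond the scatter). The dose needed is therefore sensitive to the group at this position, and the step is beyond the usual scatter. Even so, this position takes a group of 5 heavy atoms in place of 1 heavy atom, with 0 hydrogen-bond donors in place of 1, and compound 3 still gives 0.2 mg/kg in this assay. No measured information on any property of these groups accounts for the size of this step.

The compounds shown leave open which part of allyl(methyl)amino carries the step, as the allyl and methyl groups enter together and neither methylamino nor allylamino stands among them at this position. They also leave open whether a longer chain on this nitrogen, or a cyclic amine such as pyrrolidine, would lie closer to compound 2 or to compound 3 in this assay.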